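This account rests on a few compounds, and the source may have more. Where it says the series, first, only, none or still open, it means among the compounds named here.

Compounds measured so far:
Compound 1, `CSc1ccc(S(=O)(=O)NC(=O)Nc2ccc(Cl)cc2)s1`, gives 62% in a functional assay on the whole organism (6C3HED cells, Mus musculus) for inhibition, at a dose of 300 mg/kg by the oral route; a lower number here means less inhibition, a higher number more inhibition at the dose given (going by the name of the read-out).
Compound 2, `CCc1ccsc1S(=O)(=O)NC(=O)Nc1ccc(Cl)cc1`, gives 25% in this assay.

For the measured compounds named here, compound 2 stands lowest of the two numbers; its only neighbour is compound 1, and the step of a number 37 percentage points lower from compound 1 to compound 2 (beyond the scatter) lies beyond the scatter. Compound 3, `COc1csc(S(=O)(=O)NC(=O)Nc2ccc(Cl)cc2)c1`, has not yet been measured. It differs from compound 2 in one place: 4-methoxythiophen-2-yl in place of 3-ethylthiophen-2-yl on a sulfonyl sulfur.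

A single measured step bears on this change, a number 37 percentage points lower from compound 1 to compound 2 (beyond the scatter), which also exchanged the group on the sulfonyl sulfur and proved large. That step shows that swapping one substituted thiophene for another at this position can move the number substantially, but it gives no direction for the present exchange, as the entering group has not been measured before. The expected step of a number 20 percentage points higher from compound 2 to compound 3 (beyond the scatter) is therefore a moderate rise with wide uncertainty, leaning upward because compound 1 gives 62% with a different substituted thiophene in the same place. Compound 3 is expected to give 45%, within a range from 15% to 75%.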

Compound 3, a percentage reported as inhibition, in the whole organism at one dose (the size of the read-out at that dose, not a potency): 69%
For compound 3 the middle estimate is 24 percentage points below the measured one, within the range that was stated.
By their numbers in this assay, from the lowest: compound 2; then compounds 1 and 3 (each within the scatter of the next).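

At the sulfonyl sulfur, the exchange of 3-ethylthiophen-2-yl for 4-methoxythiophen-2-yl gives a number 44 percentage points higher from compound 2 to compound 3 (beyond the scatter) in this assay and shows that a change of group here can raise the number as well as lower it. Set against 5-(methylsulfanyl)thiophen-2-yl, the same entering group gives a number 7 percentage points higher from compound 1 to compound 3 (within the scatter) and so leaves two differently substituted thiophenes level with each other, while 3-ethylthiophen-2-yl alone stands apart among the three compounds. Nothing available here accounts for the gap between that group and the other two.

The three groups differ both in the substituent they carry and in where their names place it, so the compounds shown cannot separate these two changes, and a pair such as 3-methoxythiophen-2-yl against 3-ethylthiophen-2-yl would be needed to do so. On these data alone, it also remains open whether the number at this position would hold with a thiophene bearing an amine, a carboxylic acid or a longer chain such as butyl in place of the methoxy group.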